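This account rests on a few compounds, and the source may have more. Where it says the series, first, only, none or still open, it means among the compounds named here.

Two compounds here share one core and differ only in how the 1H-indol-2-yl group is tethered to it. Compound 1 `COc1ccc2nccc(C3CN(CCCNCc4cc5ccccc5[nH]4)C(=O)O3)c2c1` gives 1580 nM in an in vitro functional assay on RBL cells for antagonist activity at C-C chemokine receptor type 8 (Homo sapiens), read by FLIPR and calcium flux; a higher number here means a weaker inhibitor, a lower number a stronger inhibitor. Compound 2 `COc1ccc2nccc(C3CN(C4CCN(Cc5cc6ccccc6[nH]5)CC4)C(=O)O3)c2c1` gives 25.1 nM in this assay, the lowest of the two numbers, and its gap to compound 1 lies well beyond the scatter. Compound 3 `COc1ccc2nccc(C3CN(C4CCN(CCCc5ccccc5)CC4)C(=O)O3)c2c1` has not yet been measured; it carries phenethyl in place of 1H-indol-2-yl on a saturated chain carbon bound to an amine nitrogen in a ring. Within the data shown here, no measured step of this kind exists. With the 1H-indol-2-yl group and its hydrogen-bond donor gone, compound 3 is expected to inhibit more weakly, by a 6.4-fold higher number from compound 2 to compound 3 (0.80 log units; beyond the scatter). Compound 3 is therefore estimated at 160 nM, between 40 nM and 800 nM.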

Compound 3, half-maximal inhibitory concentration: 251 nM
Compound 3: the middle estimate sits 1.6-fold (0.20 log units) below what was measured; the range from low to high includes it.
By their numbers in this assay, from the lowest: compound 2; then compound 3; then compound 1.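

The change from (1H-indol-2-yl)methyl to 3-phenylpropyl in this assay gives a 10-fold higher number from compound 2 to compound 3 (1.00 log units; beyond the scatter). This shows that, with the tether held constant, the group on a saturated chain carbon bound to an amine nitrogen in a ring still affects the reading, which compound 1 and compound 2 could not show. The step changes both the aromatic rings and the chain, so the compounds shown cannot separate the two; a benzyl or 3-(1H-indol-2-yl)propyl group would pull them apart. Nothing supplied accounts for the size of this step.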